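Amide aryl variation in an indolyl azo series

The source may report more compounds than this note shows. Statements on the series, on what has been measured and on what is new or still open speak of the compounds shown alone.

Measured compounds:
compound 1 `O=C(Nc1ccccc1[N+](=O)[O-])c1ccc(/N=N\c2c[nH]c3ccccc23)cc1`: 208000 nM
compound 2 `Cc1ccc(NC(=O)c2ccc(/N=N\c3c[nH]c4ccccc34)cc2)c(C)c1`: 76100 nM

In a functional assay on HCT-116 cells (Homo sapiens) for inhibition, read by MTT assay, with a stated time of 72 h (on this read-out lower numbers stand for stronger inhibition and higher numbers for weaker inhibition), compound 2 gives 76100 nM, the lowest of the two numbers; its nearest neighbour is compound 1, which gives 208000 nM. Compound 3 `Cc1ccccc1NC(=O)c1ccc(/N=N\c2c[nH]c3ccccc23)cc1` is not yet measured. It differs from compound 2 by hydrogen in place of methyl on an aromatic carbon, on an aromatic carbon of a six-membered aromatic ring of carbon only, meta to a methyl group and para to a large group. Within the data shown here, the only measured step, a 2.7-fold lower number from compound 1 to compound 2 (0.44 log units; beyond the scatter), exchanges the whole aryl amide substituent and does not isolate the loss of a single methyl, so it bears on this change only loosely. Among the measured compounds shown here, no step of this kind is available. Compound 3 is therefore expected to stay close to compound 2, with at most a slight drift toward a higher number, a 1.3-fold higher number from compound 2 to compound 3 (0.12 log units; within the scatter). The estimate for compound 3 is 100000 nM, ranging from 40000 nM to 250000 nM.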

Compound 3, half-maximal inhibitory concentration: 509000 nM
For compound 3 the middle estimate is 5.1-fold (0.71 log units) below the measured one, and the stated range ends below it.
By their numbers in this assay, from the lowest: compound 2; then compound 1; then compound 3.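

In this assay this aromatic carbon, para to a large group, proves sensitive: hydrogen in place of methyl gives a 6.7-fold higher number from compound 2 to compound 3 (0.83 log units; beyond the scatter) and so isolates a single-methyl effect that the earlier whole-aryl exchange could not show. Methyl in place of nitro, with no second methyl present, gives a 2.4-fold higher number from compound 1 to compound 3 (0.39 log units; beyond the scatter) and so runs opposite to the earlier exchange, which means the lower number of compound 2 relative to compound 1 depends on the added methyl and not on the loss of nitro alone. No measurement on hand accounts for the effect of either change.

The compounds shown leave open whether a methoxy group, a chlorine atom or a longer chain on this carbon would act as methyl does. Also open, from the compounds shown here alone, is whether this methyl would lower the number with nitro in place of the other methyl.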